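Swapping a small acyl group for a carbamate

The source may hold more compounds than are shown below. What is called first, only, known or untested is meant among the compounds shown, and "the series" means these compounds.

Three compounds share one core and were tested in an assay on CHO cells for displacement of a labelled ligand from Alpha-1B adrenergic receptor (Homo sapiens), with a stated time of 30 min; on this read-out lower numbers stand for stronger inhibition and higher numbers for weaker inhibition. Compound 1 `COc1cc2nc(N3CCN(C(C)=O)[C@@H]4CCCC[C@@H]43)nc(N)c2cc1OC` gives 0.741 nM there and stands second highest of the three numbers. Its mirror image, compound 2 `COc1cc2nc(N3CCN(C(C)=O)[C@H]4CCCC[C@H]43)nc(N)c2cc1OC`, gives 9.12 nM; the step of a 12-fold higher number from compound 1 to compound 2 (1.09 log units; beyond the scatter) is large, and it rests solely on (the fact that compounds 1 and 2 differ only in the configuration as drawn). Compound 3 `CCCN(CCC)c1nc(N2CCN(C(=O)c3ccco3)[C@H]3CCCC[C@H]32)nc2cc(OC)c(OC)cc12` gives 0.302 nM but differs from compound 1 in more than one place, so no single step can be read from it.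

Compound 4 `COc1cc2nc(N3CCN(C(=O)OCc4ccccc4)[C@@H]4CCCC[C@@H]43)nc(N)c2cc1OC` carries benzyloxy in place of methyl on a carbonyl carbon. Going by the values given here, no measured step changes this group, so nothing gauges its size, and the step from compound 1 is expected to be a 1.3-fold higher number from compound 1 to compound 4 (0.13 log units; within the scatter). Compound 4 is therefore estimated at 1 nM, in a range from 0.3 nM to 3.5 nM.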

Compound 4, inhibition constant: 0.191 nM
For compound 4 the middle estimate is 5.2-fold (0.72 log units) above the measured one; measured number below the stated range.
By their numbers in this assay, from the lowest: compounds 4 and 3 (each within the scatter of the next); then compound 1; then compound 2.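

Benzyloxy in place of methyl on the carbonyl carbon strengthens inhibition in this assay (a 3.9-fold lower number from compound 1 to compound 4 (0.59 log units; beyond the scatter)), so this position accepts a far larger group carrying an aromatic ring and still gains. Nothing shown here accounts for that gain.

The compounds shown leave open whether the gain comes from the aromatic ring or from the added oxygen: a methoxy or a benzyl group on the same carbonyl carbon would separate the two. Going by these compounds, it also remains open whether benzyloxy brings the same gain in the mirror-image series of compound 2.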